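A New Phenyl Group on the Carbonyl Carbon

The source may hold more compounds than are shown below. What is called first, only, known or untested is meant among the compounds shown, and "the series" means these compounds.

In a functional assay on HepG2 cells (Homo sapiens) for inhibition, read by MTT assay (a lower number here means a stronger inhibitor of growth, a higher number a weaker inhibitor of growth), compound 1 (`COc1cc2oc(-c3cccc(NC(=O)c4ccc([N+](=O)[O-])cc4)c3)cc(=O)c2c(OC)c1OC`) gives 18800 nM and compound 2 (`COc1cc2oc(-c3cccc(NC(=O)c4ccc(C#N)cc4)c3)cc(=O)c2c(OC)c1OC`) gives 10200 nM while compound 3 (`COc1cc2oc(-c3cccc(NC(=O)c4cccc(C#N)c4)c3)cc(=O)c2c(OC)c1OC`) gives 11900 nM within the scatter of both. Compound 4 (`COC(=O)c1ccc(C(=O)Nc2cccc(-c3cc(=O)c4c(OC)c(OC)c(OC)cc4o3)c2)cc1`) has 4-(methoxycarbonyl)phenyl in place of 3-cyanophenyl on a carbonyl carbon. The measured steps are small: a 1.8-fold lower number from compound 1 to compound 2 (0.27 log units; within the scatter) and a 1.6-fold lower number from compound 1 to compound 3 (0.20 log units; within the scatter) both stay within the scatter. Given the equally small a 1.2-fold higher number from compound 2 to compound 3 (0.07 log units; within the scatter) on that same carbonyl carbon, no step beyond the scatter is expected in this assay for this change, although no measured compound carries the methoxycarbonyl group. The expected step is a 1.1-fold higher number from compound 3 to compound 4 (0.04 log units; within the scatter) by this estimate. Compound 4 is estimated at 13000 nM (range 6500 nM to 26000 nM).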

Compound 4, concentration for 50% growth inhibition: > 100000 nM
Compound 4: a limit, no number (the forecaster's own chance of this, stated with the estimate: 5%); at least 7.6-fold (0.88 log units) between middle value and limit.
By their numbers in this assay, from the lowest: compounds 2, 3 and 1 (each within the scatter of the next). At a limit, above all of these: compound 4.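

In this assay compound 4 gives > 100000 nM, which is a limit and not a number. Until now, changes to the phenyl group on this carbonyl carbon had stayed within the scatter, but this change does not: the record shows an at least 8.4-fold higher number from compound 3 to compound 4 (0.92 log units; beyond the scatter), an at least 9.8-fold higher number from compound 2 to compound 4 (0.99 log units; beyond the scatter) and an at least 5.3-fold higher number from compound 1 to compound 4 (0.72 log units; beyond the scatter). This position therefore responds to the group placed there, and methoxycarbonyl stands apart from both cyano and nitro.

On these data alone, the true size of these steps remains open, since compound 4 has only a limit. Also open, as far as these compounds go, is whether a carboxylic acid or a primary amide in place of methoxycarbonyl would give a number like that of compound 4 or those of compounds 1, 2 and 3.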